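This account rests on a few compounds, and the source may have more. Where it says the series, first, only, none or still open, it means among the compounds named here.

Working notes on the series. Compound 1 `CCOC(=O)/C=C/c1ccc(OC(=O)c2nc(C)c(C)nc2C)c(O)c1` and compound 2 `CCOC(=O)/C=C/c1ccc(OC(=O)c2nc(C)c(C)nc2C)c(OC)c1` share one core and differ only in the group on the ring oxygen. In a functional assay on EA.hy 926 cells (Homo sapiens) for cytotoxicity, read by MTT assay, with stated times of 24 h and 12 h, tested at 25 uM (on this read-out lower numbers stand for a weaker effect and higher numbers for a stronger effect at the one concentration tested), compound 1 gives 207% and compound 2 gives 53.3%. The step of a number 153.7 percentage points lower from compound 1 to compound 2 (beyond the scatter) is the only one measured so far. Among the compounds with values here, compound 2 therefore stands lowest of the two numbers in this assay, with compound 1 as its only neighbour, far above it.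

Compound 3 `CCOC(=O)/C=C/c1ccc(OC(=O)c2nc(C)c(C)nc2C)cc1` is next: hydrogen in place of methoxy on an aromatic carbon. The measured step from compound 1 to compound 2 touches the same ring position, but it exchanges hydroxyl for methoxy, whereas here the methoxy is removed outright, so it bears on the question only indirectly. What it does show is that the high number belongs to the free hydroxyl of compound 1; compound 3, like compound 2, has none. A step of a number 6.7 percentage points higher from compound 2 to compound 3 (within the scatter) within or close to the scatter is therefore expected in this assay, with no clear direction. For compound 3 the expected value in this assay is 60%, with a range from 25% to 130%.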

Compound 3, a percentage reported as activity, at one concentration (the size of the read-out at that concentration, not a potency): 58.8%
The estimate for compound 3 lay 1.2 percentage points above the measured number, and the stated range covers the measured number.
By their numbers in this assay, from the lowest: compounds 2 and 3 (each within the scatter of the next); then compound 1.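

In this assay there is a number 5.5 percentage points higher from compound 2 to compound 3 (within the scatter), so on this aromatic carbon methoxy and hydrogen cannot be told apart, and the earlier drop from the hydroxy compound cannot be read as something the methoxy adds. Replacing the hydroxy with hydrogen outright gives a number 148.2 percentage points lower from compound 1 to compound 3 (beyond the scatter), which places the high number with the hydroxy itself and not merely with its exchange for methoxy: among these three compounds, the number is high only where the hydroxy is present, and neither of the two replacements keeps it. No measured evidence is available to explain the effect of the hydroxy on this read-out.

Still open, going by these compounds, is whether another group on this carbon, such as an amine or a carboxylic acid, would keep the high number of compound 1 or fall level with compound 2 and compound 3. Also open, on these data alone, is whether a longer chain on the ring oxygen, such as ethoxy, would stay level with the methoxy of compound 2, and whether a hydroxy on a different carbon of this ring would give a high number at all.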